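This account rests on a few compounds, and the source may have more. Where it says the series, first, only, none or still open, it means among the compounds named here.

Measured so far in a functional assay on ECa-109 cells for inhibition, with ECa-109 cell line (Homo sapiens) as the target, read by sulforhodamine B assay; on this read-out higher numbers stand for weaker inhibition and lower numbers for stronger inhibition:

Compound 1, `COc1cccc(NC2=CC(=O)c3c(nc4n3[C@H]3OC[C@@H](O)[C@H]3OC4)C2=O)c1` — 3340 nM
Compound 2, `O=C1C=C(Nc2ccc(C(F)(F)F)cc2)C(=O)c2c1nc1n2[C@H]2OC[C@@H](O)[C@H]2OC1` — 5500 nM
Compound 3, `CCOc1ccccc1NC1=CC(=O)c2nc3n(c2C1=O)[C@H]1OC[C@@H](O)[C@H]1OC3` — 4630 nM

Compound 1 gives the lowest of the three numbers in this assay, but the distances to compound 3 and to compound 2 are both within the usual scatter, so the three compounds cannot be separated on these data. The next compound, compound 4, `O=C1C(Nc2ccc(I)cc2)=CC(=O)c2c1nc1n2[C@H]2OC[C@@H](O)[C@H]2OC1`, carries the change (4-iodophenyl in place of 3-methoxyphenyl on an amine nitrogen). For the measured compounds named here, the one measured step that bears on it is the exchange of one aryl group for another on the same amine nitrogen, a 1.2-fold lower number from compound 2 to compound 3 (0.07 log units; within the scatter), which did not move the number beyond the scatter. Going by the values given here, with only that step as a guide, the swap of 3-methoxyphenyl for 4-iodophenyl is expected to leave the number close to that of compound 1. The step of a 1.2-fold higher number from compound 1 to compound 4 (0.08 log units; within the scatter) is therefore expected to stay within the scatter. Compound 4 is thus estimated at 4000 nM, with a likely range from 1500 nM to 11000 nM.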

Compound 4, half-maximal inhibitory concentration: 2530 nM
The estimate for compound 4 lay 1.6-fold (0.20 log units) above the measured number; low and high end bracket the measured number.
By their numbers in this assay, from the lowest: compounds 4, 1, 3 and 2 (each within the scatter of the next, the first and the last beyond it).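

In this assay, the exchange of 3-methoxyphenyl for 4-iodophenyl on the amine nitrogen gives a 1.3-fold lower number from compound 1 to compound 4 (0.12 log units; within the scatter), so a second aryl swap at this position cannot be told from the scatter. Together with the earlier exchange, a 1.2-fold lower number from compound 2 to compound 3 (0.07 log units; within the scatter), this shows that four different substituted phenyl groups on this nitrogen, 3-methoxyphenyl, 4-iodophenyl, 2-ethoxyphenyl and 4-(trifluoromethyl)phenyl, all give numbers in the same narrow band, with no single step leaving the scatter. Nothing measured alongside these numbers accounts for the result.

All the compounds shown keep a phenyl ring on this nitrogen, so it remains open whether a simple alkyl chain, a pyridine ring or a phenyl ring bearing a carboxylic acid would move the number beyond the scatter. From the compounds shown here alone, whether changes to the shared core, away from this amine, would do so also remains open.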